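Swapping Nitro for Methoxycarbonyl on a Fused Ring

The compounds below may be only part of what the source reports. "The series", "measured", "known", "first", "only" and "open" are said of these compounds alone.

Compound 1 `Nc1ccccc1NC(=O)c1ccc(CSC(=S)N2CCN(c3ccc(Cl)cc3)CC2)cc1`, compound 3 `COc1ccc(N2CCN(C(=S)SCc3ccc(C(=O)Nc4ccccc4N)cc3)CC2)cc1` and compound 2 `Nc1ccccc1NC(=O)c1ccc(CSC(=S)N2CCc3cc([N+](=O)[O-])ccc32)cc1` were each tested in a functional assay on A-375 cells (Homo sapiens) for antiproliferative activity, read by CCK-8 assay, with a stated time of 72 h, tested at 2 uM; a lower number here means a weaker effect, a higher number a stronger effect of the compound at the concentration tested. Compound 1 gives 32.2% and compound 3 gives 28.1%; the step between them, a number 4.1 percentage points lower from compound 1 to compound 3 (within the scatter), comes from methoxy in place of chloro on an aromatic carbon. Compound 2 gives 16.9%, the lowest of the three numbers, and its gap to compound 3 as well as to compound 1 lies beyond the scatter.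

Compound 4 `COC(=O)c1ccc2c(c1)CCN2C(=S)SCc1ccc(C(=O)Nc2ccccc2N)cc1` has not yet been measured. It differs from compound 2 in one place: methoxycarbonyl in place of nitro on an aromatic carbon. Among the measured compounds shown here, no measured step concerns this kind of exchange; the single known step, from compound 1 to compound 3, is a different swap on a different part of the molecule and stayed within the scatter. The data therefore give no direction, and the expected step is one within the scatter, a number 3.1 percentage points higher from compound 2 to compound 4 (within the scatter). Compound 4 is estimated at 20%, with a range from 8% to 34%.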

Compound 4, a percentage reported as inhibition, at one concentration (the size of the read-out at that concentration, not a potency): 37.5%
For compound 4 the middle estimate is 17.5 percentage points below the measured one; the measured number lies above the stated range.
By their numbers in this assay, from the lowest: compound 2; then compounds 3, 1 and 4 (each within the scatter of the next).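

In this assay, methoxycarbonyl in place of nitro on this aromatic carbon of the fused system gives a number 20.6 percentage points higher from compound 2 to compound 4 (beyond the scatter), so the group at this position can change the read-out by more than the usual scatter. Among the compounds shown here, the earlier compounds could not show this, since their only step lay on a different part of the molecule and stayed within the scatter. Nitro and methoxycarbonyl have the same counts of hydrogen-bond donors and acceptors, so those counts do not separate them, and nothing measured here explains the difference.

Going by these compounds, whether the higher number depends on the whole ester remains open; a carboxylic acid or a primary amide at this carbon would test that. On these data alone, an amine there would show whether nitro is unusually poor, and because each number comes from one concentration, potency also stays unknown.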